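Carbamate aryl halogen swap: fluoro to chloro

A few compounds are considered here, and "the series" means these few. Any claim that something is new, unique, unknown or untested is made for them only; others in the source may bear on it.

Compound 1 `CC(C)=CCC/C(C)=C/CC1Cc2c(OCCCNC(=O)c3cccs3)cc(=O)n(CCCO)c2CC1(C)C`: 11.5%
Compound 2 `COc1cccc(NC(=O)Oc2cc(=O)n(CCCO)c3c2CC(C/C=C(\C)CCC=C(C)C)C(C)(C)C3)c1`: 11.3%
Compound 3 `CC(C)=CCC/C(C)=C/CC1Cc2c(OC(=O)Nc3ccc(F)c(Cl)c3)cc(=O)n(CCCO)c2CC1(C)C`: 0%

In a functional assay on PANC-1 cells (Homo sapiens) for inhibition, read by MTT assay, with a stated time of 24 h, tested at 10 uM (a lower number here means less inhibition, a higher number more inhibition at the concentration tested (going by the name of the read-out)), compound 3 gives 0%, the lowest of the three numbers. Within the data shown here, compound 1 gives 11.5% and compound 2 gives 11.3%, two values within the scatter of each other, so the only steps beyond the scatter are a number 11.5 percentage points lower from compound 1 to compound 3 (beyond the scatter) and a number 11.3 percentage points lower from compound 2 to compound 3 (beyond the scatter); the step of a number 0.2 percentage points lower from compound 1 to compound 2 (within the scatter) is within it.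

Compound 4 `CC(C)=CCC/C(C)=C/CC1Cc2c(OC(=O)Nc3ccc(Cl)c(Cl)c3)cc(=O)n(CCCO)c2CC1(C)C` differs from compound 3 by chloro in place of fluoro on an aromatic carbon. Among the measured compounds shown here, no measured pair shows a halogen-for-halogen exchange, so the bearing steps are indirect: the exchange of the whole aryl group on the amide-type nitrogen, a number 11.3 percentage points lower from compound 2 to compound 3 (beyond the scatter), moved the read-out by a modest amount, and that was a larger structural change than the one here. Compound 3 also sits at the bottom of what this read-out reports, which leaves little room downward. A step in this assay within the scatter is therefore expected, if anything slightly upward.

Compound 4 is expected to give 4%, between 0% and 14%. The expected step is a number 4 percentage points higher from compound 3 to compound 4 (within the scatter).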

Compound 4, a percentage reported as inhibition, at one concentration (the size of the read-out at that concentration, not a potency): 0%
The estimate for compound 4 lay 4 percentage points above the measured number, within the range that was stated.
By their numbers in this assay, from the lowest: compounds 3 and 4 (each within the scatter of the next); then compounds 2 and 1 (each within the scatter of the next).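

In this assay, among these compounds, the first direct halogen-for-halogen exchange, chloro in place of fluoro on the aromatic carbon para to a large group and ortho to a chloro group, gives no change at the digits printed from compound 3 to compound 4 (within the scatter). The 3,4-dichlorophenyl carbamate thus sits with the 3-chloro-4-fluorophenyl carbamate, and the gaps to the other two compounds remain: a number 11.3 percentage points lower from compound 2 to compound 4 (beyond the scatter) and a number 11.5 percentage points lower from compound 1 to compound 4 (beyond the scatter). No measurement at hand offers an explanation for the unchanged number.

With compound 3 and compound 4 both at the bottom of what this read-out reports, any difference between fluoro and chloro at this position remains unresolved. As far as these compounds go, whether an amine or a carboxylic acid in place of the halogen would lift the number from that level stays open.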